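Replacing a terminal bromine with hydroxyl on a quinoline-free core

The source may hold more compounds than are shown below. What is called first, only, known or untested is meant among the compounds shown, and "the series" means these compounds.

Compound 2 `OCC#CCSc1cnc2ccccc2c1SCC#CCBr` gives 36.2 ug/mL in a functional assay on SW707 cells (Homo sapiens) for cytotoxicity, read by sulforhodamine B assay, with a stated time of 72 h (on this read-out higher numbers stand for weaker inhibition and lower numbers for stronger inhibition), the highest of the three numbers measured. Compound 1 `OCC#CCSc1cnc2ccccc2c1Cl` gives 6.2 ug/mL, and the change a 5.8-fold higher number from compound 1 to compound 2 (0.77 log units; beyond the scatter) is modest. Compound 3 `OCC#CCSc1cnc2ccccc2c1[Se]CC#CCO` gives 26.6 ug/mL; the step of a 1.4-fold lower number from compound 2 to compound 3 (0.13 log units; within the scatter) lies within the scatter, though that pair differs in two places at once. Compound 4 `OCC#CCSc1cnc2ccccc2c1SCC#CCO` is reached by a single change, (hydroxy in place of bromo on a saturated chain carbon bound to a triple-bonded carbon). Among the compounds with values here, no measured step isolates this change; the nearest comparison, from compound 2 to compound 3, is small. Compound 4 is therefore expected to show a step of a 1.2-fold lower number from compound 2 to compound 4 (0.08 log units; within the scatter), that is, no shift beyond the scatter. The estimated value for compound 4 is 30 ug/mL, within a range from 12 ug/mL to 75 ug/mL.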

Compound 4, concentration for 50% inhibition: 32 ug/mL
Compound 4: the middle estimate sits 1.1-fold (0.03 log units) below what was measured; measured number inside the range.
By their numbers in this assay, from the lowest: compound 1; then compounds 3, 4 and 2 (each within the scatter of the next).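

In this assay, hydroxy in place of bromo on a saturated chain carbon bound to a triple-bonded carbon gives no shift beyond the scatter (a 1.1-fold lower number from compound 2 to compound 4 (0.05 log units; within the scatter)). Sulfur in place of selenium as the linking atom is just as silent (a 1.2-fold higher number from compound 3 to compound 4 (0.08 log units; within the scatter)), while the step away from the chlorine stays beyond the scatter (a 5.2-fold higher number from compound 1 to compound 4 (0.71 log units; beyond the scatter)). Nothing here explains these results. From the compounds shown here alone, whether an amine or a carboxylic acid at that chain end, or a longer chain, would move the number remains open.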